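Nitrotriazole to nitroimidazole: notes on tolerance in Vero cells

The source may report more compounds than this note shows. Statements on the series, on what has been measured and on what is new or still open speak of the compounds shown alone.

Measured in an ADME assay on Vero cells (Chlorocebus sabaeus) for cytotoxicity, read by luminescence and CellTiter-Glo, with a stated time of 2 days; a lower number here means that less compound is tolerated, a higher number that more compound is tolerated:
- compound 1 `O=[N+]([O-])c1ncn(CCCCNc2ncnc3ccccc23)n1`: > 100 uM
- compound 2 `O=[N+]([O-])c1ncn(CCCCNc2ccnc3c(Cl)cccc23)n1`: "not determined" (no result reported)

Not yet measured:
- compound 3 `O=[N+]([O-])c1nccn1CCCCNc1ccnc2c(Cl)cccc12`

The value of compound 1, > 100 uM, is a limit of the assay and not a number. Compound 2 has no number to place: its entry reads "not determined" (no result reported). The only reference is therefore (the limit of > 100 uM in this assay, at which 1 of the 2 values shown sits).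

The change 2-nitro-1H-imidazol-1-yl in place of 3-nitro-1H-1,2,4-triazol-1-yl on a saturated chain carbon, four bonds along the chain from a nitrogen on an aromatic ring puts 2-nitro-1H-imidazol-1-yl in place of 3-nitro-1H-1,2,4-triazol-1-yl on a saturated chain carbon.

Within the data shown here, no measured step informs this change, so no shift beyond the usual scatter is expected in this assay, in either direction.

For compound 3 the estimated value is 60 uM, with an expected range of 20 uM to 100 uM.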

Compound 3, half-maximal toxic concentration: 66 uM
The estimate for compound 3 lay 1.1-fold (0.04 log units) below the measured number, and the stated range covers the measured number.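

No step can be read between compound 3 and compound 2: the entry for compound 2 reads "not determined" (no result reported). As far as these compounds go, whether 2-nitro-1H-imidazol-1-yl in place of 3-nitro-1H-1,2,4-triazol-1-yl shifts tolerance on the shared core stays open.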